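Phthalide series: replacing the ether tail of compound 3

The source may hold more compounds than are shown below. What is called first, only, known or untested is meant among the compounds shown, and "the series" means these compounds.

Compound 1 `O=C1OC(Cc2nc(-c3ccccc3)no2)c2ccccc21` gives > 10000 nM in a functional assay on RAW264.7 cells (Mus musculus) for inhibition, read by Griess assay, with stated times of 1 h and 24 h (a higher number here means a weaker inhibitor, a lower number a stronger inhibitor), which is a limit of the assay and not a number. Compound 2 `O=C1OC(Cc2nc(-c3ccc(-c4ccccc4)cc3)no2)c2ccccc21` gives > 10000 nM in this assay, again a limit. The step that the two limits leave unreadable from compound 1 to compound 2 therefore cannot be read, because both ends rest at the limit of > 10000 nM in this assay, at which 2 of the 3 values shown sit. Within the data shown here, compound 3 `COCCCOc1ccc(C(O)C2OC(=O)c3c(OC)cc(OC)cc32)cc1` stands as the only member with a number: in this assay compound 3 gives 1260 nM.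

Compound 4 `COc1cc(OC)c2c(c1)C(C(O)c1ccc(OCc3ccc(C#N)cc3)cc1)OC2=O` has not been measured. It differs from compound 3 by 4-cyanophenyl in place of 2-methoxyethyl on a saturated chain carbon bound to an oxygen on an aromatic ring; cut one bond further out, the change reads 3-methoxypropoxy to (4-cyanobenzyl)oxy. Among the measured compounds shown here, no measured step touches this part of the molecule, and the one step that exists is unreadable, so the data give no direction for the change. The step of a 1.1-fold lower number from compound 3 to compound 4 (0.02 log units; within the scatter) is therefore expected to stay within the scatter, and the range is kept wide. Compound 4 is expected at 1200 nM in this assay, between 300 nM and 5000 nM.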

Compound 4, half-maximal inhibitory concentration: 7360 nM
Estimate against measurement, compound 4: 6.1-fold (0.79 log units) below; the whole stated range lies below it.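

This position responds to the tail: in this assay, 4-cyanophenyl in place of 2-methoxyethyl on the saturated chain carbon bound to an oxygen on an aromatic ring gives a 5.8-fold higher number from compound 3 to compound 4 (0.77 log units; beyond the scatter), a step beyond the scatter. Among these compounds, it is the first readable step, as the step between the two earlier limit compounds cannot be read, and it shows that this tail is not freely exchangeable on the shared core. The data shown give no measured property that accounts for this step.

Open, going by these compounds, is whether the step follows the nitrile or the added aromatic ring, which a plain benzyl tail would separate. Also open, on these data alone, is whether a 3-methoxypropyl tail ending in an amine or a carboxylic acid instead of the methoxy group would shift the number in either direction.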